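The compounds below may be only part of what the source reports. "The series", "measured", "known", "first", "only" and "open" are said of these compounds alone.

Compound 1 `CC(=O)NS(=O)(=O)c1ccc(N/C(S)=N\c2ccnc3cc(C(F)(F)F)ccc23)cc1` — 58600 nM
Compound 2 `O=S(=O)(Nc1nccs1)c1ccc(N/C(S)=N\c2ccnc3cc(C(F)(F)F)ccc23)cc1` — 24400 nM

Both numbers come from a functional assay on MDA-MB-231 cells (Homo sapiens) for antiproliferative activity, read by sulforhodamine B assay, with a stated time of 48 h; a higher number here means a weaker inhibitor, a lower number a stronger inhibitor. Compound 1 stands highest of the two numbers, with compound 2 nearest. Among the compounds with values here, the single measured step is a 2.4-fold lower number from compound 1 to compound 2 (0.38 log units; beyond the scatter), from 1,3-thiazol-2-yl in place of acetyl on a sulfonamide nitrogen.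

Compound 3 `COc1ncnc(NS(=O)(=O)c2ccc(N/C(S)=N\c3ccnc4cc(C(F)(F)F)ccc34)cc2)c1OC` differs from compound 1 by 5,6-dimethoxypyrimidin-4-yl in place of acetyl on a sulfonamide nitrogen. Once more an aromatic heterocycle replaces acetyl at the same sulfonamide nitrogen, so that one step is the only guide, and a modest lower number is expected: a 2.3-fold lower number from compound 1 to compound 3 (0.37 log units; beyond the scatter). For compound 3 the estimate is 25000 nM, with a range from 9000 nM to 70000 nM.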

Compound 3, half-maximal inhibitory concentration: 83000 nM
The estimate for compound 3 lay 3.3-fold (0.52 log units) below the measured number; the measured number lies above the stated range.
By their numbers in this assay, from the lowest: compound 2; then compounds 1 and 3 (each within the scatter of the next).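

An aromatic heterocycle on the sulfonamide nitrogen does not lower the number by itself: 5,6-dimethoxypyrimidin-4-yl in place of acetyl gives a 1.4-fold higher number from compound 1 to compound 3 (0.15 log units; within the scatter) and so leaves compound 3 level with compound 1. Between the two heterocycles the change gives a 3.4-fold higher number from compound 2 to compound 3 (0.53 log units; beyond the scatter), so the gain at this position is confined to the 1,3-thiazol-2-yl of compound 2 among these compounds. Nothing measured here accounts for the difference between the two rings.

Still open, as far as these compounds go, is whether the methoxy groups or the pyrimidine ring itself set the value of compound 3. A pyrimidin-4-yl without methoxy groups, or a plain hydrogen on the sulfonamide nitrogen, would separate these readings.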